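The source may hold more compounds than are shown below. What is called first, only, known or untested is meant among the compounds shown, and "the series" means these compounds.

Measured so far in a functional assay on LN-229 cells (Homo sapiens) for antiproliferative activity, with a stated time of 72 h; a higher number here means a weaker inhibitor, a lower number a stronger inhibitor:
Compound 1 `Nc1ncnn2c([C@@H]3O[C@H](CO)[C@@H](O)[C@H]3O)cc(C#Cc3cccs3)c12`: > 100000 nM (a limit)
Compound 2 `Nc1ncnn2c([C@@H]3O[C@H](CO)[C@@H](O)[C@H]3O)cc(/C=C/c3ccccc3)c12`: 3900 nM

Compound 1 is known only through a limit, (the limit of > 100000 nM in this assay, at which 1 of the 2 values shown sits). Among the compounds with values here, compound 2 therefore carries the only actual number so far.

Compound 3 `Nc1ncnn2c([C@@H]3O[C@H](CO)[C@@H](O)[C@H]3O)cc(-c3ccsc3)c12` has thiophen-3-yl in place of 2-phenylethenyl on an aromatic carbon.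

Within the data shown here, the one measured step at this place on the shared core is an at least 25-fold lower number from compound 1 to compound 2 (1.40 log units; beyond the scatter). It shows that a change here can move this assay by a large amount, but it gives no direction for thiophen-3-yl, a group carried by neither compound 1 nor compound 2. The central expectation is therefore no step beyond the scatter, with wide uncertainty in both directions. The expected step is a 1.6-fold lower number from compound 2 to compound 3 (0.19 log units; within the scatter). For compound 3 the estimated value is 2500 nM, with an expected range of 200 nM to 50000 nM.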

Compound 3, half-maximal inhibitory concentration: 57700 nM
Compound 3: middle estimate off by 23-fold (1.36 log units), on the low side, outside the stated range (above it).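

At this position on the shared core, thiophen-3-yl in place of 2-phenylethenyl gives a clearly weaker result in this assay (a 15-fold higher number from compound 2 to compound 3 (1.17 log units; beyond the scatter)). The earlier step gave no direction for a thiophene ring attached directly to the core; this one does, and compound 2 is now the strongest of the three, with its steps to both others printed as beyond the scatter. The comparison with compound 1 (an at least 1.7-fold lower number from compound 1 to compound 3 (0.23 log units; that floor lies within the scatter)) establishes no order between compound 1 and compound 3, and compound 1 is known only through a limit: the limit of > 100000 nM in this assay, at which 1 of the 3 values shown sits.

Going by these compounds, what a plain phenyl group or a saturated 2-phenylethyl chain would give at this position remains open. The stronger value of compound 2 therefore cannot yet be assigned to its benzene ring, its double bond or its chain length.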